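Fluoro to Methoxy: An Expectation for Compound 4

The compounds below may be only part of what the source reports. "The series", "measured", "known", "first", "only" and "open" are said of these compounds alone.

Among the compounds with values here, compound 3 `CCCCCCCCCCn1cc(/C=C/C(=O)c2ccc(NC(=O)CN3CCN(c4ccccc4F)CC3)cc2)nn1` is one of three compounds measured in a functional assay on HeLa cells (Homo sapiens) for inhibition, read by MTT assay; a lower number here means a stronger inhibitor, a higher number a weaker inhibitor. Compound 3 gives 47800 nM, the second highest of the three numbers; compound 1 `CCCCCCCCCCn1cc(/C=C/C(=O)c2ccc(NC(=O)CN3CCN(c4ccccc4)CC3)cc2)nn1` gives 59100 nM and compound 2 `CCCCCCCCn1cc(/C=C/C(=O)c2ccc(NC(=O)CN3CCN(c4ccccc4OC)CC3)cc2)nn1` gives 26800 nM, both within the scatter of compound 3. Compound 4 `CCCCCCCCCCn1cc(/C=C/C(=O)c2ccc(NC(=O)CN3CCN(c4ccccc4OC)CC3)cc2)nn1` differs from compound 3 by methoxy in place of fluoro on an aromatic carbon. Within the data shown here, only one single-point step has been measured, a 1.2-fold lower number from compound 1 to compound 3 (0.09 log units; within the scatter), and it did not move the number beyond the scatter. Compound 2 carries the methoxy group but on a shorter chain, so its value gives only a hint. A small change is expected, a 1.5-fold lower number from compound 3 to compound 4 (0.17 log units; within the scatter). The estimate for compound 4 is 32000 nM, within a range from 12000 nM to 80000 nM.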

Compound 4, half-maximal inhibitory concentration: 50800 nM
Compound 4: the middle estimate sits 1.6-fold (0.20 log units) below what was measured; measured number inside the range.
By their numbers in this assay, from the lowest: compounds 2, 3, 4 and 1 (each within the scatter of the next, the first and the last beyond it).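

In this assay, methoxy in place of fluoro gives a 1.1-fold higher number from compound 3 to compound 4 (0.03 log units; within the scatter), and methoxy in place of hydrogen gives a 1.2-fold lower number from compound 1 to compound 4 (0.07 log units; within the scatter), so on this aromatic carbon, ortho to a large group, neither change moves the number beyond the scatter. Ethyl in place of hydrogen on the saturated chain gives a 1.9-fold higher number from compound 2 to compound 4 (0.28 log units; within the scatter), which also stays within the scatter. No measurement is available to explain these small steps. As far as these compounds go, whether an amine or a carboxylic acid on this aromatic carbon, or a longer chain, would shift the number beyond the scatter remains open.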